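A few compounds are considered here, and "the series" means these few. Any claim that something is new, unique, unknown or untested is made for them only; others in the source may bear on it.

Compound 1, `CC(=O)C1=C(C)NC(=O)NC1c1ccsc1`: 1%
Compound 2, `CC1=C(C(=O)OC2CCC2)C(c2ccsc2)NC(=O)N1`: 3%

Of the compounds shown here, two with a shared core have been tested in an assay on membranes from HeLa cells for displacement of a labelled ligand from adenosine receptor A3 (Homo sapiens), read by scintillation counting, with a stated time of 180 min, tested at 1 uM; a lower number here means less inhibition, a higher number more inhibition at the concentration tested (going by the name of the read-out). In that test compound 1 gives 1%, and compound 2 gives 3%. Compound 2 thus stands level with compound 1: the step of a number 2 percentage points higher from compound 1 to compound 2 (within the scatter) lies within the scatter, so the two cannot be told apart, even though it brought cyclobutyloxy in place of methyl on a carbonyl carbon. Both numbers are small, meaning little displacement of the labelled ligand at the concentration tested.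

Compound 3, `CC1=C(C(=O)OC2CCCC2)C(c2ccsc2)NC(=O)N1`, differs from compound 2 in one place: cyclopentyl in place of cyclobutyl on an oxygen next to a carbonyl group. Going by the values given here, the only measured step that bears on this region is a number 2 percentage points higher from compound 1 to compound 2 (within the scatter), which changed the same position far more drastically and still stayed within the scatter. Adding a single carbon to the ring is a smaller change, so no step beyond the scatter is expected in this assay, in either direction.

Compound 3 is therefore expected to give 3%, with a range from -5% to 12%. The expected step is no change at the digits printed from compound 2 to compound 3 (within the scatter).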

Compound 3, a percentage reported as inhibition, at one concentration (the size of the read-out at that concentration, not a potency): 5%
Compound 3: the middle estimate sits 2 percentage points below what was measured; the range from low to high includes it.
By their numbers in this assay, from the lowest: compounds 1, 2 and 3 (each within the scatter of the next).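

Replacing cyclobutyl with cyclopentyl on an oxygen next to a carbonyl group gives a number 2 percentage points higher from compound 2 to compound 3 (within the scatter) in this assay, so these two ring sizes cannot be told apart at this position. The wider change, swapping the methyl on the carbonyl carbon for cyclopentyloxy, gives a number 4 percentage points higher from compound 1 to compound 3 (within the scatter), which shows that even this larger swap of the group on the carbonyl carbon does not separate the two compounds in this test. No other measurement shown here helps to interpret these results.

The three compounds leave open whether any group at this position can produce a step beyond the scatter, and an amine or a carboxylic acid at the end of a longer chain on the same oxygen would be a very different kind of test from these carbon rings. Each number also comes from one concentration and so is not a potency, which leaves open how these compounds would compare at other concentrations.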